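Chloro to trifluoromethyl on the benzylic ring of compound 2

The source may report more compounds than this note shows. Statements on the series, on what has been measured and on what is new or still open speak of the compounds shown alone.

Two thioamide sulfonamides have been measured in a functional assay for antagonist activity at transient receptor potential cation channel subfamily V member 1 (Rattus norvegicus); a higher number here means a weaker inhibitor, a lower number a stronger inhibitor. Compound 1 `CC(C)(C)c1ccc(CCC(=S)NCc2ccc(NS(C)(=O)=O)c(F)c2)cc1` gives 40 nM in this assay. Compound 2 `CC(C)(C)c1ccc(CCC(=S)NCc2ccc(NS(C)(=O)=O)cc2Cl)cc1` gives 3500 nM in this assay, the higher of the two numbers, and the gap to compound 1 is well beyond the scatter. The two compounds differ from each other in more than one place, so the gap cannot be tied to a single change.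

Compound 3 `CC(C)(C)c1ccc(CCC(=S)NCc2ccc(NS(C)(=O)=O)cc2C(F)(F)F)cc1` is the next member and has not yet been measured in this assay. It differs from compound 2 by trifluoromethyl in place of chloro on an aromatic carbon, a trifluoromethyl in place of chloro on an aromatic carbon. Within the data shown here, no measured pair isolates this change, so there is nothing in the data that points in either direction. The expectation is a step from compound 2 to compound 3 of a 1.2-fold lower number from compound 2 to compound 3 (0.07 log units; within the scatter), none beyond the scatter. Compound 3 is therefore estimated at 3000 nM in this assay, with a range from 800 nM to 12000 nM.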

Compound 3, half-maximal inhibitory concentration: 2400 nM
For compound 3 the middle estimate is 1.3-fold (0.10 log units) above the measured one, and the stated range covers the measured number.
By their numbers in this assay, from the lowest: compound 1; then compounds 3 and 2 (each within the scatter of the next).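

In this assay, among these compounds, trifluoromethyl in place of chloro on this aromatic carbon, ortho to a large group and meta to a methanesulfonamido group, gives a 1.5-fold lower number from compound 2 to compound 3 (0.16 log units; within the scatter) for the first isolated change. Compound 2 and compound 3 therefore cannot be told apart in this read-out, although trifluoromethyl brings 4 heavy atoms where chloro had 1 heavy atom, so this pair gives no sign that the read-out depends on which of these two groups occupies the position. No independent measurement bears on why the two groups read alike.

The compounds shown leave open how this aromatic carbon would read with a methoxy group, a nitrile or an amine, or with only hydrogen, and so whether any group here can move the number beyond the scatter. As far as these compounds go, compound 1 differs from compound 2 in more than one place, so the part of their gap that belongs to this position also remains open.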